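Shifting a Chlorine Around an Aryl Ring

This account rests on a few compounds, and the source may have more. Where it says the series, first, only, none or still open, it means among the compounds named here.

The two measured compounds:
compound 1, `COc1cc(-n2ncnc2-c2ccccc2)cc(OC)c1OC`, > 10000 nM
compound 2, `COc1cc(-n2ncnc2-c2ccc(Cl)cc2)cc(OC)c1OC`, > 10000 nM

In a functional assay on K562 cells (Homo sapiens) for antiproliferative activity, read by MTT assay, with a stated time of 72 h (a higher number here means a weaker inhibitor, a lower number a stronger inhibitor), compound 1 reaches only the limit of the test, reported as > 10000 nM. In this assay compound 2 likewise gives only a limit, > 10000 nM. Compound 2 therefore stands at the weak end of what this test can read, with no number of its own, and both values sit at the limit of > 10000 nM in this assay, at which 2 of the 2 values shown sit. For the measured compounds named here, the one measured step, a step that the two limits leave unreadable from compound 1 to compound 2, is of unknown size, since neither of its ends is a number.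

Compound 3, `COc1cc(-n2ncnc2-c2cccc(Cl)c2)cc(OC)c1OC`, is not yet measured. It differs from compound 2 by 3-chlorophenyl in place of 4-chlorophenyl on an aromatic carbon. Going by the values given here, no measured step of this kind is available: the only step in hand connects two limits and cannot be read. With nothing to suggest a gain, the expected step that the limit leaves unreadable from compound 2 to compound 3 is estimated as none beyond the scatter. Compound 3 is most likely expected to reach only the limit again. The estimate for compound 3 in this assay is 20000 nM, within 8000 nM to 60000 nM.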

Compound 3, half-maximal inhibitory concentration: > 10000 nM
Compound 3: no number, only a limit (the forecaster's own chance of this, stated with the estimate: 85%); the middle value lies beyond the limit too.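

Compound 3 gives only a limit in this assay, > 10000 nM, and not a number. No step among compound 1, compound 2 and compound 3 can therefore be read, as all three values sit at the same limit: the limit of > 10000 nM in this assay, at which 3 of the 3 values shown sit.

As far as these compounds go, whether 3-chlorophenyl in place of 4-chlorophenyl, or chloro in place of hydrogen, changes the activity at all remains open.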